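This account rests on a few compounds, and the source may have more. Where it says the series, first, only, none or still open, it means among the compounds named here.

Compound 1 `CC(C)Nc1ncnc2c1ncn2Cc1ccccc1F` and compound 2 `CC(C)(C)Nc1ncnc2c1ncn2Cc1ccccc1F` share one core and differ only in the group on the nitrogen on the aromatic ring. In a functional assay on the whole organism with Rattus norvegicus as the target, in the maximal electroshock model (on this read-out lower numbers stand for an effect already at smaller amounts and higher numbers for an effect only at larger amounts of compound), compound 1 gives 5.8 mg/kg. For compound 2 the value in this assay is a limit of the assay, > 50 mg/kg. Of the two values shown, one sits at the limit of > 50 mg/kg in this assay, at which 1 of the 2 values shown sits. The step of an at least 8.6-fold higher number from compound 1 to compound 2 (0.93 log units; beyond the scatter) therefore runs toward higher doses, and compound 2 stands at that limit, without a number of its own.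

Compound 3 `Fc1ccccc1Cn1cnc2c(NCC3CC3)ncnc21` is not yet measured. It differs from compound 2 by cyclopropylmethyl in place of tert-butyl on a nitrogen on an aromatic ring. For the measured compounds named here, the only measured step that bears on this change is an at least 8.6-fold higher number from compound 1 to compound 2 (0.93 log units; beyond the scatter), in which a methyl in place of hydrogen on the chain carbon bound to the nitrogen gave a much higher number. Compound 3 removes the tert-butyl, and its cyclopropylmethyl again carries hydrogens on the chain carbon bound to the nitrogen, as the isopropyl of compound 1 does, so the step of an at least 5.0-fold lower number from compound 2 to compound 3 (0.69 log units; beyond the scatter) is expected to run back toward lower doses. Compound 3 is therefore estimated at 10 mg/kg, within a range from 3 mg/kg to 40 mg/kg.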

Compound 3, dose for half-maximal effect: 4.3 mg/kg
Compound 3: the middle estimate sits 2.3-fold (0.37 log units) above what was measured; the measured number falls inside the stated range.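

With an at least 11-fold lower number from compound 2 to compound 3 (1.06 log units; beyond the scatter) in this assay, the outcome at this nitrogen on an aromatic ring is not set by the size of the group as counted, since tert-butyl and cyclopropylmethyl each hold 4 heavy atoms. The second step, a 1.3-fold lower number from compound 1 to compound 3 (0.13 log units; within the scatter), means that cyclopropylmethyl and isopropyl cannot be told apart on this read-out, so among the three compounds only the tert-butyl of compound 2 stands apart, and a three-membered ring on the chain goes with an effect at doses like those of compound 1. The first of these steps remains a bound rather than a measured size, as compound 2 has only a limit of the assay: the limit of > 50 mg/kg in this assay, at which 1 of the 3 values shown sits.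

The compounds shown leave open whether a 2,2-dimethylpropyl group, which has hydrogens on the chain carbon bound to the nitrogen and a fully branched carbon one place further out, would read like compound 3 or like compound 2. They also leave open how a longer chain such as n-butyl, or a cyclopropyl bound directly to the nitrogen, would read on the shared core.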